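The compounds below may be only part of what the source reports. "The series", "measured", "known", "first", "only" and "open" are said of these compounds alone.

Measured compounds:
Compound 1 `COc1ccc(/C=C\C(=O)O)c(OCc2cn(-c3ccc(NC(C)=O)cc3)nn2)c1CC=C(C)C` gives 22600 nM in a functional assay on COLO 205 cells (Homo sapiens) for cytotoxicity, read by MTT assay, with a stated time of 24 h; a higher number here means a weaker inhibitor, a lower number a stronger inhibitor.
Compound 2 `COc1ccc(-n2cc(COc3c(/C=C\C(=O)O)ccc(OC)c3CC=C(C)C)nn2)cc1` gives "not determined" (no result reported) in this assay, that is, no result is reported for it.
Compound 3 `COc1ccc(/C=C\C(=O)O)c(OCc2cn(-c3ccccc3I)nn2)c1CC=C(C)C` gives "not determined" (no result reported) in this assay, that is, no result is reported for it.

Within the data shown here, compound 3 therefore stands without a number in this assay, and compound 2 is in the same position, so the only figure on record is the one for compound 1, which puts that compound among weak inhibitors on this read-out. Among the measured compounds shown here, nothing can be said about how compound 3 compares with compound 1, since the pair has no measured step.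

Compound 4 `COc1ccc(/C=C\C(=O)O)c(OCc2cn(-c3nc4ccccc4s3)nn2)c1CC=C(C)C` differs from compound 3 in one place: 1,3-benzothiazol-2-yl in place of 2-iodophenyl on an aromatic nitrogen. For the measured compounds named here, no step between measured compounds is available to anchor the size of this change. With only the weak figure of compound 1 as a guide to the series, the author expects compound 4 to land in the same weak region, and treats any shift from the unknown value of compound 3 as most likely within the scatter, or at most a modest move in either direction. The estimate for compound 4 in this assay is 20000 nM, with a range from 6000 nM to 60000 nM.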

Compound 4, half-maximal inhibitory concentration: 20200 nM
For compound 4 the middle estimate is 1.0-fold (0.00 log units) below the measured one; the measured number falls inside the stated range.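

In this assay, the series now has its first measured step at this position, a 1.1-fold lower number from compound 1 to compound 4 (0.05 log units; within the scatter) and so within the scatter: on the aromatic nitrogen of the five-membered ring, 1,3-benzothiazol-2-yl and 4-acetamidophenyl cannot be told apart on this read-out, although the two groups differ in their ring make-up and side group. Going by these compounds, compound 2 and compound 3 carry no number, so the steps that lead to or from them cannot be read, and what the change from 2-iodophenyl does remains unknown. No measurement at hand accounts for the close agreement between the two groups.

The compounds shown leave open whether any group on this nitrogen can move the number beyond the scatter, since the two readable groups are both aromatic and both give figures in the same weak region. A simple alkyl chain such as n-butyl in place of the aromatic group, or an amine on the phenyl ring in place of the acetamido group, would test how far this insensitivity extends.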